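Swapping the Aryl Group on a Weak Antiproliferative Lead

This account rests on a few compounds, and the source may have more. Where it says the series, first, only, none or still open, it means among the compounds named here.

Compound 1 `CNC(=O)c1cc(Oc2ccc(NC(=O)c3cc4cccnc4n(-c4ccc(Br)cc4)c3=O)cc2)ccn1`: 15000 nM
Compound 2 `CNC(=O)c1cc(Oc2ccc(NC(=O)c3cc4cccnc4n(-c4ccc(OC)cc4)c3=O)cc2)ccn1`: "not determined" (no result reported)

In a functional assay on U-87MG ATCC cells for antiproliferative activity against U-87 MG (Homo sapiens), read by MTT assay, with a stated time of 72 h (a lower number here means a stronger inhibitor, a higher number a weaker inhibitor), compound 1 gives 15000 nM, a weak result. Compound 2 was tested but returned no number, so it cannot be placed on any scale here. Compound 3 `CNC(=O)c1cc(Oc2ccc(NC(=O)c3cc4cccnc4n(-c4ccc(C(F)(F)F)cc4Cl)c3=O)cc2)ccn1` differs from compound 2 by 2-chloro-4-(trifluoromethyl)phenyl in place of 4-methoxyphenyl on an aromatic nitrogen. For the measured compounds named here, no measured step of this kind exists in this assay, so only a modest shift, if any beyond the scatter, is expected, with compound 1 serving as the sole anchor for the series. Compound 3 is estimated at 6000 nM, expected to fall between 1000 nM and 30000 nM.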

Compound 3, half-maximal inhibitory concentration: 19800 nM
Estimate against measurement, compound 3: 3.3-fold (0.52 log units) below, within the range that was stated.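

In this assay, putting 2-chloro-4-(trifluoromethyl)phenyl in place of 4-bromophenyl on the aromatic nitrogen gives a 1.3-fold higher number from compound 1 to compound 3 (0.12 log units; within the scatter), so the two compounds cannot be told apart. This position therefore accepts two differently substituted phenyl groups, and the result stays weak with both. No available evidence explains this result.

Compound 2 has no number, so steps to or from it cannot be read. From the compounds shown here alone, it remains open whether a phenyl ring carrying an amine or a carboxylic acid, or a longer alkyl chain in place of the ring, would give a clearly different value.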